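Amide aryl swaps on the shared core

The source may report more compounds than this note shows. Statements on the series, on what has been measured and on what is new or still open speak of the compounds shown alone.

Compound 1 `Cc1ccc(NC(=O)c2cccc(Cl)c2)cc1-n1cc(-c2cccnc2)cn1` serves as the reference. Among the measured compounds shown here, in a functional assay on K562 cells (Homo sapiens) for inhibition, read by MTT assay, with a stated time of 48 h (on this read-out higher numbers stand for weaker inhibition and lower numbers for stronger inhibition), compound 1 gives 1320 nM, the lowest of the two numbers so far, and its nearest neighbour is compound 2 `Cc1ccc(NC(=O)c2ccc(F)cc2)cc1-n1cc(-c2cccnc2)cn1`, which in this assay gives 12500 nM. For the measured compounds named here, the single measured step, a 9.5-fold higher number from compound 1 to compound 2 (0.98 log units; beyond the scatter), shows that exchanging the 3-chlorophenyl for a 4-fluorophenyl on the carbonyl carbon weakens inhibition clearly, though only modestly in size.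

Compound 3 `COc1ccc(C(=O)Nc2ccc(C)c(-n3cc(-c4cccnc4)cn3)c2)cc1` carries the change (4-methoxyphenyl in place of 3-chlorophenyl on a carbonyl carbon). Going by the values given here, the only step that bears on it is the one from compound 1 to compound 2, since both replace the same 3-chlorophenyl on the carbonyl carbon with a ring of the 4-fluorophenyl or 4-methoxyphenyl kind; no compound with a 4-methoxyphenyl has yet been measured, so the transfer is uncertain. A weakening of similar, modest size in this assay is therefore expected, direction upward. Compound 3 is expected to give 6000 nM in this assay, with a range of 1800 nM to 20000 nM, which would be a step of a 4.5-fold higher number from compound 1 to compound 3 (0.66 log units; beyond the scatter).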

Compound 3, half-maximal inhibitory concentration: 18300 nM
Compound 3: middle estimate off by 3.1-fold (0.48 log units), on the low side; measured number inside the range.
By their numbers in this assay, from the lowest: compound 1; then compounds 2 and 3 (each within the scatter of the next).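

In this assay, a second replacement of the 3-chlorophenyl on the carbonyl carbon, this time by 4-methoxyphenyl, gives a 14-fold higher number from compound 1 to compound 3 (1.14 log units; beyond the scatter) and so moves the number the same way as the 4-fluorophenyl did: among the three compounds, both rings carrying a group at their 4-position stand above compound 1, and none goes against this. Methoxy in place of fluoro on an aromatic carbon gives a 1.5-fold higher number from compound 2 to compound 3 (0.17 log units; within the scatter), so compound 2 and compound 3 cannot be told apart here, and the change of substituent on that ring makes no readable difference in this pair. Nothing at hand explains why either replacement of the 3-chlorophenyl weakens inhibition.

Compound 1 differs from compound 2 and compound 3 in both the identity of the substituent and its place on the ring, so these compounds cannot show which of the two matters. A 4-chlorophenyl or a 3-methoxyphenyl on the same carbonyl carbon would separate them, and an unsubstituted phenyl or a ring bearing an amine would show how much the substituent contributes at all.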